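A few compounds are considered here, and "the series" means these few. Any claim that something is new, unique, unknown or untested is made for them only; others in the source may bear on it.

Measured so far in an assay on IMR-32 cells for displacement of a labelled ligand from corticotropin-releasing factor receptor 1 (Homo sapiens), read by scintillation counting, with a stated time of 2 h; a higher number here means a weaker inhibitor, a lower number a stronger inhibitor:
compound 1, `CCc1nc(-c2ccc(OC(F)(F)F)cc2OC)c(CC)nc1NC(CC)CC`: 7.2 nM
compound 2, `CCc1nc(-c2ccc(OC(F)(F)F)cc2OC)c(OC)nc1NC(CC)CC`: 6.1 nM

Among the measured compounds shown here, compound 1 gives one of only two numbers known here, and the number for compound 2 lies within the usual scatter of it: a 1.2-fold lower number from compound 1 to compound 2 (0.07 log units; within the scatter). That single step swaps a group on the shared core, so the two compounds cannot be told apart in this assay.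

Compound 3, `CCc1nc(-c2ccc(C)cc2OC)c(CC)nc1NC(CC)CC`, is not yet measured. It differs from compound 1 by methyl in place of trifluoromethoxy on an aromatic carbon; the site is meta to a methoxy group and para to a large group. For the measured compounds named here, the only measured step, from compound 1 to compound 2, leaves the trifluoromethoxy untouched and therefore says nothing about replacing it. Going by the values given here, no measured pair shows what this exchange does, so the expectation rests on the change itself, with a range wider than the scatter. The step expected here is a 1.7-fold higher number from compound 1 to compound 3 (0.22 log units; within the scatter). Compound 3 is estimated to give 12 nM in this assay, between 4 nM and 40 nM.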

Compound 3, inhibition constant: 23.7 nM
Compound 3: middle estimate off by 2.0-fold (0.30 log units), on the low side; the measured number falls inside the stated range.
By their numbers in this assay, from the lowest: compounds 2 and 1 (each within the scatter of the next); then compound 3.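

In this assay the exchange of trifluoromethoxy for methyl, on the aromatic carbon para to a large group, gives a 3.3-fold higher number from compound 1 to compound 3 (0.52 log units; beyond the scatter) and is the first change shown here that moves the number beyond the usual scatter. Among the compounds shown here, the earlier pair, which differs at another place on the shared core, could not be told apart, so this is the first site where the choice of group shows up in the binding numbers, although the step is only modest and compound 3 still gives 23.7 nM in this range of low numbers. No measurement offered here accounts for the step, so its size is known and its cause is not.

This single exchange removes the oxygen and the three fluorines together, so a trifluoromethyl group or a chlorine atom at the same place would be needed to show which part of the change carries the step. From the compounds shown here alone, it also remains open whether the same exchange made on compound 2, with its methoxy on the core, would give a step of similar size.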